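Pyrazolyl for thiophenyl on the benzyl arm of a urea

The compounds below may be only part of what the source reports. "The series", "measured", "known", "first", "only" and "open" are said of these compounds alone.

Compound 1 `O=C(Nc1c(F)cc(F)cc1F)N(Cc1ccc(-c2cccs2)cc1)C1CCCCCC1`: 18 nM
Compound 2 `Cc1cc(C)c(NC(=O)N(Cc2cccc(-c3nn[nH]n3)c2)C2CCCCCC2)c(C)c1`: > 1000 nM
Compound 3 `Cc1cc(C)c(NC(=O)N(Cc2ccc(-c3cccs3)cc2)C2CCCCCC2)c(C)c1`: 22 nM

In an assay on microsomes from intestine for inhibition of acyl-CoA:cholesterol acyltransferase (Oryctolagus cuniculus) (on this read-out higher numbers stand for weaker inhibition and lower numbers for stronger inhibition), compound 3 stands highest of the two numbers, with compound 1 nearest at a 1.2-fold higher number from compound 1 to compound 3 (0.09 log units; within the scatter). For compound 2 only a limit is reported, at the limit of > 1000 nM in this assay, at which 1 of the 3 values shown sits. Compound 4 `Cc1cc(C)c(NC(=O)N(Cc2ccc(-n3cccn3)cc2)C2CCCCCC2)c(C)c1` carries 1H-pyrazol-1-yl in place of thiophen-2-yl on an aromatic carbon. For the measured compounds named here, the one measured step, from compound 1 to compound 3, swaps the aryl on the amide-type nitrogen and leaves the thiophenyl end untouched, so no measured step bears directly on this change; compound 2 shows only that a different azole on the benzyl ring, at a different position, gave a limit. The step of a 4.1-fold higher number from compound 3 to compound 4 (0.61 log units; beyond the scatter) is therefore expected as a moderate weakening. Compound 4 is estimated at 90 nM, between 20 nM and 500 nM.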

Compound 4, half-maximal inhibitory concentration: 70 nM
Estimate against measurement, compound 4: 1.3-fold (0.11 log units) above, and the stated range covers the measured number.
By their numbers in this assay, from the lowest: compounds 1 and 3 (each within the scatter of the next); then compound 4. At a limit, above all of these: compound 2.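

In this assay, 1H-pyrazol-1-yl in place of thiophen-2-yl gives a 3.2-fold higher number from compound 3 to compound 4 (0.50 log units; beyond the scatter), so this position responds to which five-membered aromatic ring it carries. Both groups have 5 heavy atoms, so the step comes with a change in the kind of ring atoms, not their number. Nothing measured here says why the number rises. On these data alone, how a plain phenyl or a pyridyl ring would fare at this position stays open. So does whether the same swap gives a similar step with 2,4,6-trifluorophenyl on the amide-type nitrogen.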